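The compounds below may be only part of what the source reports. "The series", "measured", "known", "first", "only" and "open" are said of these compounds alone.

Compounds measured so far in a physicochemical assay for acid dissociation:
- compound 1 `CCCN(C1=NCCN1)c1c(Br)cccc1Br`, which gives 11
- compound 2 `CCCCCN(C1=NCCN1)c1c(Br)cccc1Br`, which gives 11
- compound 3 `CC(C)CCN(C1=NCCN1)c1c(Br)cccc1Br`, which gives 10.9

Compound 1 stands level with compound 2 at the digits printed, the two of them together the highest of the three numbers; its nearest neighbour is compound 2, with no change at the digits printed from compound 1 to compound 2 (within the scatter), and its furthest is compound 3, with a number 0.10 log units lower from compound 1 to compound 3 (within the scatter). Compound 2 and compound 3 are separated by a number 0.10 log units lower from compound 2 to compound 3 (within the scatter). Every step seen so far leaves this assay unchanged beyond the scatter.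

The unmeasured compound 4 `C#CCN(C1=NCCN1)c1c(Br)cccc1Br` differs from compound 1 in one place: ethynyl in place of ethyl on a saturated chain carbon bound to a nitrogen on an aromatic ring. Going by the values given here, none of the measured steps touches a triple bond; they only lengthen or branch a saturated chain, and each of them stayed within the scatter. They therefore offer no direct guide. The author expects a modest lowering, a number 0.70 log units lower from compound 1 to compound 4 (beyond the scatter), and estimates compound 4 at 10.3, within a range from 9.6 to 10.9.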

Compound 4, acid dissociation constant: 10.1
Beside the measured number, compound 4's estimate is 0.20 log units above it, and the stated range covers the measured number.
By their numbers in this assay, from the lowest: compound 4; then compounds 3, 1 and 2 (each within the scatter of the next).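

In this assay, the place on a saturated chain carbon bound to a nitrogen on an aromatic ring now shows a step beyond the scatter, which lengthening or branching the saturated chain had not produced: ethynyl in place of ethyl gives the clearest reading (a number 0.90 log units lower from compound 1 to compound 4 (beyond the scatter)). The result is the same whichever saturated chain serves as the reference, with ethynyl in place of isobutyl (a number 0.80 log units lower from compound 3 to compound 4 (beyond the scatter)) and ethynyl in place of butyl (a number 0.90 log units lower from compound 2 to compound 4 (beyond the scatter)), so only the change to the triple bond separates compounds here. No measurement at hand explains this shift.

The compounds shown leave open whether a triple bond is needed, since an allyl group or a nitrile at the same place would test that. As far as these compounds go, it also remains open whether the step would hold with chlorine in place of the bromine atoms on the shared core.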